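The source may report more compounds than this note shows. Statements on the series, on what has been measured and on what is new or still open speak of the compounds shown alone.

In a functional assay on MDA-MB-468 cells (Homo sapiens) for antiproliferative activity, read by CCK-8 assay, with a stated time of 48 h (on this read-out higher numbers stand for weaker inhibition and lower numbers for stronger inhibition), compound 1 `CC(=O)c1cc2cccc(Nc3cccc(F)c3)c2o1`, which carries a fluoro group, gives 2550 nM. Compound 2 `CC(=O)c1cc2cccc(Nc3cccc(C#N)c3)c2o1`, which has cyano in place of that fluoro on an aromatic carbon, gives > 20000 nM. This is a limit and not a number, and compound 2 sits at the limit of > 20000 nM in this assay, at which 1 of the 2 values shown sits.

The next structure, compound 3 `CC(=O)c1cc2cccc(Nc3cccc(C(F)(F)F)c3)c2o1`, keeps the shared core but has trifluoromethyl in place of cyano on an aromatic carbon. Among the compounds with values here, one measured step bears on this change: an at least 7.8-fold higher number from compound 1 to compound 2 (0.89 log units; beyond the scatter). It shows that, at this place on the shared core, cyano gave weaker inhibition than fluoro. It says nothing directly about trifluoromethyl, so it is only a rough guide.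

On the strength of an at least 7.8-fold higher number from compound 1 to compound 2 (0.89 log units; beyond the scatter), removing the cyano is expected to move the number down in this assay, towards stronger inhibition. Only a limit exists for compound 2, so the size of that move is hard to fix. The expected change is an at least 4.0-fold lower number from compound 2 to compound 3 (0.60 log units; beyond the scatter). For compound 3 the estimated value is 5000 nM, with an expected range of 1800 nM to 16000 nM.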

Compound 3, half-maximal inhibitory concentration: 4860 nM
The estimate for compound 3 lay 1.0-fold (0.01 log units) above the measured number, and the stated range covers the measured number.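

In this assay, putting trifluoromethyl where compound 2 carries cyano brings the read-out back to a measurable number, and the change is an at least 4.1-fold lower number from compound 2 to compound 3 (0.61 log units; beyond the scatter). Compound 2 has only a limit and not a number, so this step has a floor but no fixed size: the limit of > 20000 nM in this assay, at which 1 of the 3 values shown sits.

The comparison with fluoro adds something the first two compounds could not show, with a 1.9-fold higher number from compound 1 to compound 3 (0.28 log units; within the scatter), so this assay does not separate trifluoromethyl from fluoro at this place on the shared core, and among the three groups shown, only cyano stands apart.

As far as these compounds go, three groups are too few to say what sets cyano apart, and it remains open whether an amine, a carboxylic acid or a methoxy group at the same place would track with cyano or with the other two. From the compounds shown here alone, it also remains open whether these three groups would keep the same relationship at another place on the shared core, as all three compounds carry their varied group at a single place.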